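The source may report more compounds than this note shows. Statements on the series, on what has been measured and on what is new or still open speak of the compounds shown alone.

In a functional assay on MDA-MB-231 cells for antagonist activity at C-X-C chemokine receptor type 4 (Homo sapiens), tested at 100 nM (a higher number here means a stronger effect of the compound at the concentration tested, a lower number a weaker effect), compound 2 `Clc1ccc(NCc2ccc(CNc3ncccn3)cc2)nc1` gives 100%, the highest of the three numbers measured here. Compound 3 `CSc1ccnc(NCc2ccc(CNc3ncc(F)cn3)cc2)n1` comes nearest with 92%, a gap that stays within the usual scatter of repeated measurements, so the two cannot be ranked against each other. Compound 1 `c1cnc(NCc2ccc(CNc3ccccc3N3CCCC3)cc2)nc1` lies furthest away with 73%, a difference beyond the scatter. Compound 4 `Fc1ccc(NCc2ccc(CNc3ncccn3)cc2)nc1` has not yet been measured; it differs from compound 2 in one place: fluoro in place of chloro on an aromatic carbon. Within the data shown here, no pair of measured compounds shows this exact change, so there is no direct step to lean on. Trading chloro for fluoro on the same aromatic carbon is a small change, so only a small step is expected, a number 10 percentage points lower from compound 2 to compound 4 (within the scatter), downward if anything, or none beyond the scatter. Compound 4 is thus estimated at 90%, between 72% and 100%.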

Compound 4, a percentage reported as inhibition, at one concentration (the size of the read-out at that concentration, not a potency): 78%
Compound 4: middle estimate off by 12 percentage points, on the high side, and the stated range covers the measured number.
By their numbers in this assay, from the lowest: compounds 1 and 4 (each within the scatter of the next); then compounds 3 and 2 (each within the scatter of the next).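

This is the first change in a single place among these compounds, and it shows that this position is sensitive even to a swap of one halogen for another. On this aromatic carbon, two atoms from the ring nitrogen, fluoro in place of chloro gives a number 22 percentage points lower from compound 2 to compound 4 (beyond the scatter) in this assay. No measurement at hand accounts for this step.

As far as these compounds go, what bromo, methyl or methoxy on the same carbon would give remains open. So does whether the same exchange would have a similar effect on another core.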